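Aryl swap at the weak end of the series

This account rests on a few compounds, and the source may have more. Where it says the series, first, only, none or still open, it means among the compounds named here.

In a functional assay on NCI-H460 cells (Homo sapiens) for antiproliferative activity, with a stated time of 72 h (on this read-out higher numbers stand for weaker inhibition and lower numbers for stronger inhibition), compound 1 `CCCCC#Cc1cc([C@@H]2O[C@H](CO)[C@@H](O)[C@H]2O)n2ncnc(N)c12` gives 1700 nM. Compound 2 `Nc1ncnn2c([C@@H]3O[C@H](CO)[C@@H](O)[C@H]3O)cc(C#Cc3ccc(F)cc3)c12` gives 79400 nM, and compound 3 `Nc1ncnn2c([C@@H]3O[C@H](CO)[C@@H](O)[C@H]3O)cc(-c3ccc(F)cc3F)c12` gives 93300 nM. Compound 3 shares the weak end of these three numbers with compound 2, and the two cannot be told apart, with a 1.2-fold higher number from compound 2 to compound 3 (0.07 log units; within the scatter). Compound 1 lies far off, with a 55-fold higher number from compound 1 to compound 3 (1.74 log units; beyond the scatter).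

Compound 4 `COc1ccc(-c2cc([C@@H]3O[C@H](CO)[C@@H](O)[C@H]3O)n3ncnc(N)c23)cc1` carries a new group on the same aromatic carbon of the five-membered aromatic ring with 1 nitrogen: 4-methoxyphenyl in place of 2,4-difluorophenyl on an aromatic carbon. The exchange is one aromatic group for another. Among the compounds with values here, the closest precedent is a 1.2-fold higher number from compound 2 to compound 3 (0.07 log units; within the scatter), where a change of group bearing a fluorinated phenyl left the number within the scatter. The large steps, a 47-fold higher number from compound 1 to compound 2 (1.67 log units; beyond the scatter) and a 55-fold higher number from compound 1 to compound 3 (1.74 log units; beyond the scatter), both start from the hex-1-yn-1-yl compound and say little about a swap among aryl groups. Within the data shown here, no measured compound here carries a 4-methoxyphenyl group, so that group remains untested. No step beyond the scatter is expected in this assay, and no direction is favoured. The estimated step is a 1.4-fold lower number from compound 3 to compound 4 (0.16 log units; within the scatter). The estimated value for compound 4 is 65000 nM, with an expected range from 20000 nM to 120000 nM.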

Compound 4, half-maximal inhibitory concentration: 69300 nM
Compound 4: middle estimate off by 1.1-fold (0.03 log units), on the low side, within the range that was stated.
By their numbers in this assay, from the lowest: compound 1; then compounds 4, 2 and 3 (each within the scatter of the next).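

In this assay, removing fluorine from the aryl group at this aromatic carbon, two ring bonds from the ring nitrogen, and adding a methoxy oxygen gives a 1.3-fold lower number from compound 3 to compound 4 (0.13 log units; within the scatter), so 4-methoxyphenyl and 2,4-difluorophenyl cannot be told apart here. The comparison with the alkynyl aryl compound, a 1.1-fold lower number from compound 2 to compound 4 (0.06 log units; within the scatter), is also within the scatter, while the comparison with the alkyl alkyne, a 41-fold higher number from compound 1 to compound 4 (1.61 log units; beyond the scatter), is large; compounds 2, 3 and 4 thus form one group, whether or not fluorine is present and whether the ring is attached directly or through a triple bond, with compound 1 alone well apart from them. No measurement on hand bears on the reason for this flat response among the aryl groups or for the separation of compound 1.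

Still open, from the compounds shown here alone, is how much of the standing of compound 1 depends on chain length or on the triple bond, which a propyl chain on the triple bond or a saturated hexyl group at the same carbon would address. Also open, going by these compounds, is whether an aryl group bearing an amine or a carboxylic acid would stay with compounds 2, 3 and 4 in this assay.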